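Exchanging the Sulfonyl Aryl Ring: Methylphenyl to Naphthyl

The source may hold more compounds than are shown below. What is called first, only, known or untested is meant among the compounds shown, and "the series" means these compounds.

Compound 1 `COc1cc(C(=O)NS(=O)(=O)c2ccccc2OC)ccc1Cn1ccc2ccc(NC(=O)CC3CCCC3)cc21`: 9.7 in a functional assay (trachea) for antagonist activity, with Cavia porcellus as the target; on this read-out higher numbers stand for higher potency (the scale is a negative logarithm) and lower numbers for lower potency
Compound 2 `COc1cc(C(=O)NS(=O)(=O)c2ccccc2C)ccc1Cn1ccc2ccc(NC(=O)CC3CCCC3)cc21`: 9.9 in this assay

Compound 2 holds the higher of the two numbers in this assay, with compound 1 nearest to it, but the step of a number 0.20 log units higher from compound 1 to compound 2 (within the scatter) lies within the scatter, so the two compounds cannot be ranked against each other. Compound 3 `COc1cc(C(=O)NS(=O)(=O)c2ccc3ccccc3c2)ccc1Cn1ccc2ccc(NC(=O)CC3CCCC3)cc21` differs from compound 2 in one place: naphthalen-2-yl in place of 2-methylphenyl on a sulfonyl sulfur. Among the compounds with values here, the only measured step, from compound 1 to compound 2, concerns a substituent on an aromatic carbon of that same ring and is small; no measured step exchanges the whole ring on the sulfonyl sulfur. The data therefore give no direct guide, and the expectation is an essentially flat step, a number 0.30 log units lower from compound 2 to compound 3 (within the scatter), with a wide range. Compound 3 is estimated at 9.6 in this assay, expected to fall between 8.8 and 10.3.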

Compound 3, negative logarithm of the antagonist equilibrium constant: 8.3
The estimate for compound 3 lay 1.30 log units above the measured number; the measured number lies below the stated range.
By their numbers in this assay, from the lowest: compound 3; then compounds 1 and 2 (each within the scatter of the next).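

In this assay, the sulfonyl sulfur proved sensitive to the exchange of the whole ring: naphthalen-2-yl in place of 2-methylphenyl gives a number 1.60 log units lower from compound 2 to compound 3 (beyond the scatter) and naphthalen-2-yl in place of 2-methoxyphenyl gives a number 1.40 log units lower from compound 1 to compound 3 (beyond the scatter) in the same direction. Within the data shown here, the earlier change of a single substituent on that ring stayed small, a number 0.20 log units higher from compound 1 to compound 2 (within the scatter) being the only step seen before, so this position does not accept every aryl group alike. Nothing at hand accounts for the drop.

The compounds shown do not separate the effect of the second aromatic ring from the loss of the methyl or methoxy group. As far as these compounds go, how a plain phenyl, a naphthalen-1-yl or a pyridyl group on the sulfonyl sulfur would compare remains open.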